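This account rests on a few compounds, and the source may have more. Where it says the series, first, only, none or still open, it means among the compounds named here.

The measured compounds are compound 1 `Fc1ccc(Cl)c(-c2cc(-c3cnn(C4CCNCC4)c3)on2)c1` with 270 nM and compound 2 `Fc1ccc(-c2cc(-c3cnn(C4CCNCC4)c3)on2)c(Cl)c1` with 220 nM in an assay on isolated protein for positive allosteric modulation of Neuronal acetylcholine receptor; alpha4/beta2 (Homo sapiens); a higher number here means that more compound is needed for the effect, a lower number that less compound is needed.

Going by the values given here, compound 2 stands beside compound 1, the only other measured compound, and the step of a 1.2-fold lower number from compound 1 to compound 2 (0.09 log units; within the scatter) leaves the two indistinguishable in this assay. Compound 3 `Clc1cccc(Cl)c1-c1cc(-c2cnn(C3CCNCC3)c2)on1` has not been measured; it differs from compound 2 by 2,6-dichlorophenyl in place of 2-chloro-4-fluorophenyl on an aromatic carbon. Among the compounds with values here, the single measured step, from compound 1 to compound 2, moved the fluorine between ring positions and stayed within the scatter; no measured step shows a fluorine exchanged for a second chlorine, so nothing bears directly on this change. With no guidance either way, the step of a 1.4-fold higher number from compound 2 to compound 3 (0.13 log units; within the scatter) is expected to stay within the scatter, with a wide range reflecting that uncertainty. Compound 3 is therefore estimated at 300 nM in this assay, between 100 nM and 900 nM.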

Compound 3, half-maximal effective concentration: 410 nM
For compound 3 the middle estimate is 1.4-fold (0.14 log units) below the measured one; the measured number falls inside the stated range.
By their numbers in this assay, from the lowest: compounds 2, 1 and 3 (each within the scatter of the next).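

Compound 3, with 2,6-dichlorophenyl on the aromatic carbon next to the ring nitrogen, is the only one of the three in which a second chlorine replaces the fluorine. In this assay, the comparison shows a 1.9-fold higher number from compound 2 to compound 3 (0.27 log units; within the scatter) and a 1.5-fold higher number from compound 1 to compound 3 (0.18 log units; within the scatter), so this exchange cannot be told apart from either fluorinated compound. At this position, therefore, the three halogenated phenyl groups shown give numbers that remain indistinguishable, whichever of the three is present, and no measurement offered here explains this result.

The compounds shown leave open whether a phenyl group without any halogen, or one carrying a methoxy group or a carboxylic acid, would fall in the same range. From the compounds shown here alone, whether a phenyl group bearing a single chlorine and no fluorine would also read the same remains open.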